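This account rests on a few compounds, and the source may have more. Where it says the series, first, only, none or still open, it means among the compounds named here.

Three compounds sharing one core have been examined in an ADME assay on MT4 cells (Homo sapiens) for cytotoxicity, read by MTT assay, with a stated time of 5 days; a lower number here means that less compound is tolerated, a higher number that more compound is tolerated. Compound 1 `Cc1cc(C#N)cc(C)c1Oc1nc(Nc2ccc(C#N)cc2)ncc1-c1ccncc1` carries a pyridin-4-yl group and gives 28000 nM. Compound 2 `Cc1cc(C#N)cc(C)c1Oc1nc(Nc2ccc(C#N)cc2)ncc1-c1cccc2ccccc12` carries a naphthalen-1-yl group in the same place, and in this assay it reaches only a limit, > 267000 nM, so no exact number is known for it. Compound 3 `Cc1cc(C#N)cc(C)c1Oc1nc(Nc2ccc(C#N)cc2)ncc1-c1cccnc1` carries a pyridin-3-yl group and gives 13500 nM, the lowest of the two exact numbers; compound 1 sits nearest, with a 2.1-fold lower number from compound 1 to compound 3 (0.32 log units; beyond the scatter) read in reverse. Compound 4 `Cc1cc(C#N)cc(C)c1Oc1nc(Nc2ccc(C#N)cc2)ncc1-c1ccc2ccccc2c1` is not yet measured. It differs from compound 3 in one place: naphthalen-2-yl in place of pyridin-3-yl on an aromatic carbon. Going by the values given here, two measured steps bear on this: swapping a pyridine ring for a naphthalene ring gave an at least 9.5-fold higher number from compound 1 to compound 2 (0.97 log units; beyond the scatter), and the reverse swap gave an at least 19-fold lower number from compound 2 to compound 3 (1.29 log units; beyond the scatter). Replacing pyridin-3-yl with naphthalen-2-yl in compound 4 is therefore expected to give a large rise, an 11-fold higher number from compound 3 to compound 4 (1.05 log units; beyond the scatter), with the estimate for compound 4 being 150000 nM, spanning 35000 nM to 400000 nM; a limit is quite possible because the limit of > 267000 nM in this assay, at which 1 of the 3 values shown sits, was reached by compound 2.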

Compound 4, half-maximal cytotoxic concentration: 8460 nM
Compound 4: the middle estimate sits 18-fold (1.25 log units) above what was measured, and the stated range ends above it.
By their numbers in this assay, from the lowest: compounds 4 and 3 (each within the scatter of the next); then compound 1. At a limit, above all of these: compound 2.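

In this assay, a naphthalene ring at this position does not by itself bring a high number: for naphthalen-2-yl in place of pyridin-3-yl, the result is a 1.6-fold lower number from compound 3 to compound 4 (0.20 log units; within the scatter), so these two groups cannot be told apart here. The point of attachment on the naphthalene counts for far more, with an at least 31-fold lower number from compound 2 to compound 4 (1.49 log units; beyond the scatter), and naphthalen-2-yl in place of pyridin-4-yl gives a 3.3-fold lower number from compound 1 to compound 4 (0.52 log units; beyond the scatter). Compound 2, the naphthalen-1-yl member, is held at a limit and not an exact number: the limit of > 267000 nM in this assay, at which 1 of the 4 values shown sits.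

The compounds shown do not explain why naphthalen-1-yl stands apart from naphthalen-2-yl. They also leave open how this position would respond to a non-aromatic group such as a primary amine, a carboxylic acid or a longer alkyl chain.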